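A Trifluoromethyl Group Added to the Shared Core

The compounds below may be only part of what the source reports. "The series", "measured", "known", "first", "only" and "open" are said of these compounds alone.

Compound 1 `Cc1c(C(=O)NCc2ccccc2)[n+]([O-])c2ccccc2[n+]1[O-]` was tested in an ADME assay on Vero cells (Chlorocebus sabaeus) for cytotoxicity, read by MTT assay, with a stated time of 72 h; a lower number here means a stronger inhibitor, a higher number a weaker inhibitor. In this assay compound 1 gives > 100 ug/mL, which is a limit of the assay rather than a number. Compound 2 `COc1ccc(CNC(=O)c2c(C)[n+]([O-])c3ccccc3[n+]2[O-])cc1` carries a methoxy in place of hydrogen on an aromatic carbon. In this assay compound 2 gives > 30 ug/mL, also a limit and not a number. The step that the two limits leave unreadable from compound 1 to compound 2 therefore cannot be read, because the limit of > 100 ug/mL in this assay, at which 1 of the 2 values shown sits, and the limit of > 30 ug/mL in this assay, at which 1 of the 2 values shown sits, leave its size open. Compound 2 thus stands only at a limit, with no numeric position among the values shown.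

Compound 3 `COc1ccc(CNC(=O)c2c(C)[n+]([O-])c3ccc(C(F)(F)F)cc3[n+]2[O-])cc1` differs from compound 2 by trifluoromethyl in place of hydrogen on an aromatic carbon. Going by the values given here, no measured step bears on a trifluoromethyl on the shared core, and the single measured step is unreadable. Compound 3 is therefore expected to remain weak in this assay, with a step that the limit leaves unreadable from compound 2 to compound 3 estimated as none beyond the scatter. Compound 3 is estimated at 60 ug/mL, within the range 20 ug/mL to 150 ug/mL.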

Compound 3, half-maximal inhibitory concentration: > 30 ug/mL
Compound 3: a limit, no number (the forecaster's own chance of this, stated with the estimate: 60%); the middle value is on the limit's open side.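

Compound 2 and compound 3 both stand at limits rather than numbers, so no step between them can be read in this assay: the limit of > 30 ug/mL in this assay, at which 2 of the 3 values shown sit.

The compounds shown leave open whether methoxy or trifluoromethyl on an aromatic carbon changes the reading in this assay at all, and where any of the three compounds lies as a number.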